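Amidoxime to semicarbazone on a halogenated nucleoside pair

A few compounds are considered here, and "the series" means these few. Any claim that something is new, unique, unknown or untested is made for them only; others in the source may bear on it.

Compound 1 `N/C(=N\O)c1c(Br)n(C2O[C@H](CO)[C@@H](O)[C@H]2O)c2cc(Cl)c(Cl)cc12` gives 35000 nM in a functional assay on KB cells (Homo sapiens) for cytotoxicity, read by spectrophotometry and crystal violet staining; on this read-out higher numbers stand for weaker inhibition and lower numbers for stronger inhibition. Compound 2 `N/C(=N\O)c1c(Cl)n(C2O[C@H](CO)[C@@H](O)[C@H]2O)c2cc(Cl)c(Cl)cc12` gives only a limit in this assay, > 100000 nM, and thus sits at the limit of > 100000 nM in this assay, at which 1 of the 2 values shown sits. Among the measured compounds shown here, the single measured step, an at least 2.8-fold higher number from compound 1 to compound 2 (0.45 log units; beyond the scatter), concerns chloro in place of bromo on an aromatic carbon and does not touch the group altered next. Compound 3 `NC(=O)N/N=C/c1c(Cl)n(C2O[C@H](CO)[C@@H](O)[C@H]2O)c2cc(Cl)c(Cl)cc12` differs from compound 2 by a group of 6 heavy atoms (2 carbon, 3 nitrogen, 1 oxygen; no ring) in place of a group of 4 heavy atoms (1 carbon, 2 nitrogen, 1 oxygen; no ring), on an aromatic carbon. For the measured compounds named here, no measured step bears on this change, so compound 3 is expected to stay near the limit, with a number no higher from compound 2 to compound 3 (the limit leaves the size open) meaning no movement beyond the scatter. The estimate for compound 3 is 100000 nM, ranging from 40000 nM to 300000 nM.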

Compound 3, half-maximal inhibitory concentration: > 100000 nM
Compound 3 gave a limit, no number; the forecaster's own chance of this, stated with the estimate: 65%; the middle value sits exactly at the limit.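

No new step can be read between compound 2 and compound 3, as both values are limits: the limit of > 100000 nM in this assay, at which 2 of the 3 values shown sit.

The compounds shown leave open how the group of 6 heavy atoms compares with the group of 4 heavy atoms on the shared core.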